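Benzodioxinyl in place of chloroethoxyphenyl: compound 3 to compound 4

The compounds below may be only part of what the source reports. "The series", "measured", "known", "first", "only" and "open" are said of these compounds alone.

Compound 3 `CCOc1ccc(-c2cc3ncn([C@H]4CCN(C(=O)N(C)[C@H]5CCN(C6CCOCC6)C5)C4)c(=O)c3s2)c(Cl)c1` stands level with compound 1 `Cc1ccc(-c2cc3ncn([C@H]4CCN(C(=O)N(C)[C@H]5CCN(C6CCOCC6)C5)C4)c(=O)c3s2)cc1` at the digits shown, the two together giving the lowest numbers of three: in an assay on isolated protein for binding affinity to melanin-concentrating hormone receptor 1 (Homo sapiens) (on this read-out lower numbers stand for stronger inhibition and higher numbers for weaker inhibition), compound 3 gives 14 nM and compound 1 gives 14 nM, while compound 2 `CN(C(=O)N1CC[C@H](n2cnc3cc(-c4ccc(C(F)(F)F)cc4)sc3c2=O)C1)[C@H]1CCN(C2CCOCC2)C1` gives 19 nM. The steps among these three were all small: a 1.4-fold higher number from compound 1 to compound 2 (0.13 log units; within the scatter), no change at the digits printed from compound 1 to compound 3 (within the scatter) and a 1.4-fold lower number from compound 2 to compound 3 (0.13 log units; within the scatter). Compound 4 `CN(C(=O)N1CC[C@H](n2cnc3cc(-c4ccc5c(c4)OCCO5)sc3c2=O)C1)[C@H]1CCN(C2CCOCC2)C1` carries 2,3-dihydro-1,4-benzodioxin-6-yl in place of 2-chloro-4-ethoxyphenyl on an aromatic carbon. Every change so far at that carbon stayed within the scatter. The step to compound 4 is therefore expected to be none beyond the scatter, a 1.1-fold higher number from compound 3 to compound 4 (0.06 log units; within the scatter). Compound 4 is estimated at 16 nM in this assay, with a range from 7 nM to 35 nM.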

Compound 4, inhibition constant: 45 nM
Compound 4: the middle estimate sits 2.8-fold (0.45 log units) below what was measured; the whole stated range lies below it.
By their numbers in this assay, from the lowest: compounds 1, 3 and 2 (each within the scatter of the next); then compound 4.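

Within the data shown here, at the aromatic carbon next to the ring sulfur, 2,3-dihydro-1,4-benzodioxin-6-yl gives the first steps beyond the scatter in this assay: a 3.2-fold higher number from compound 3 to compound 4 (0.51 log units; beyond the scatter) and a 2.4-fold higher number from compound 2 to compound 4 (0.37 log units; beyond the scatter) and a 3.2-fold higher number from compound 1 to compound 4 (0.51 log units; beyond the scatter). This position therefore does not accept every aryl group equally, although the three earlier groups could not be told apart. Nothing available explains the shift.

Open, on these data alone, is whether 3,4-dimethoxyphenyl, which keeps both oxygens without the closed ring, would match compound 4 or compound 1. As far as these compounds go, how a 4-aminophenyl group would fare there also remains open.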